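This account rests on a few compounds, and the source may have more. Where it says the series, first, only, none or still open, it means among the compounds named here.

Measured in an ADME assay on HEK293 cells (Homo sapiens) for cytotoxicity, read by MTT assay, with a stated time of 48 h; on this read-out lower numbers stand for stronger inhibition and higher numbers for weaker inhibition:
Compound 1 `O=C1/C(=C\c2ccc(O)cc2)S/C(=N/c2ccccc2)N1Cc1ccncc1`: 142000 nM
Compound 2 `CN(C)c1ccc(/C=C2/S/C(=N/c3ccccc3)N(Cc3ccncc3)C2=O)cc1`: 122000 nM
Compound 3 `CC(C)c1ccc(/C=C2/S/C(=N/c3ccccc3)N(Cc3ccncc3)C2=O)cc1`: 137000 nM

Compound 3, at 137000 nM, cannot be separated from the other two measured compounds. The comparisons show a 1.0-fold lower number from compound 1 to compound 3 (0.02 log units; within the scatter) and a 1.1-fold higher number from compound 2 to compound 3 (0.05 log units; within the scatter).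

The next compound, compound 4 `COc1ccc(/C=C2/S/C(=N/c3ccccc3)N(Cc3ccncc3)C2=O)cc1OC`, is changed in the same part of the molecule: 3,4-dimethoxyphenyl in place of 4-isopropylphenyl on a double-bonded chain carbon bound to a double-bonded ring carbon. In words, 3,4-dimethoxyphenyl replaces 4-isopropylphenyl on a double-bonded chain carbon bound to a double-bonded ring carbon.

The closest evidence comes from swaps of the group on that aromatic ring. Besides the two steps above, the data show a 1.2-fold lower number from compound 1 to compound 2 (0.07 log units; within the scatter). Hydroxy, dimethylamino and isopropyl thus gave no step beyond the scatter in these three compounds. Going by the values given here, no measured compound carries a 3,4-dimethoxyphenyl group, so the expectation stays loose, and no real step is anticipated.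

The expected change is a 1.1-fold lower number from compound 3 to compound 4 (0.02 log units; within the scatter).

For compound 4, the estimated value is 130000 nM, with an expected range of 75000 nM to 210000 nM.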

Compound 4, half-maximal inhibitory concentration: 171000 nM
Estimate against measurement, compound 4: 1.3-fold (0.12 log units) below, and the stated range covers the measured number.
By their numbers in this assay, from the lowest: compounds 2, 3, 1 and 4 (each within the scatter of the next).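

In this assay, going by these compounds alone, 3,4-dimethoxyphenyl in place of 4-isopropylphenyl gives a 1.2-fold higher number from compound 3 to compound 4 (0.10 log units; within the scatter) so bringing in oxygen atoms and hydrogen-bond acceptors, which 4-isopropylphenyl lacks, produces no step that can be told from repeat-measurement noise. The comparisons with the other two groups read the same way, with a 1.4-fold higher number from compound 2 to compound 4 (0.15 log units; within the scatter) and a 1.2-fold higher number from compound 1 to compound 4 (0.08 log units; within the scatter) so the four groups at this position on a double-bonded chain carbon cannot be separated in this test. No measured evidence is available that would explain these small differences.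

The compounds shown leave open whether a quite different group on this aromatic ring, such as a carboxylic acid or a chlorine atom, would produce a real step. They also leave open whether changes elsewhere on the shared core would matter more.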